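Swapping trifluoromethyl for an ester on a shared core

The source may hold more compounds than are shown below. What is called first, only, known or untested is meant among the compounds shown, and "the series" means these compounds.

Compound 1, `COc1ccc(-c2cc(N3CCC(CNS(N)(=O)=O)CC3)ncn2)cc1`, gives a limit of the assay in a functional assay on HT-29 cells (Homo sapiens) for antiproliferative activity, read by sulforhodamine B assay, with a stated time of 48 h; on this read-out lower numbers stand for stronger inhibition of growth and higher numbers for weaker inhibition of growth: > 100000 nM.
Compound 2, `NS(=O)(=O)NCC1CCN(c2cc(-c3ccc(Cl)cc3)ncn2)CC1`, gives 37700 nM.
Compound 3, `NS(=O)(=O)NCC1CCN(c2cc(-c3ccc(C(F)(F)F)cc3)ncn2)CC1`, gives 29100 nM.

Of the two numbers actually reported, compound 3 has the lowest, but compound 2 sits within the scatter of it, as the step of a 1.3-fold lower number from compound 2 to compound 3 (0.11 log units; within the scatter) shows; the third entry, (the limit of > 100000 nM in this assay, at which 1 of the 3 values shown sits), is a limit and not a number. Compound 4, `COC(=O)c1ccc(-c2cc(N3CCC(CNS(N)(=O)=O)CC3)ncn2)cc1`, differs from compound 3 in a single place: methoxycarbonyl in place of trifluoromethyl on an aromatic carbon. For the measured compounds named here, two measured steps touch this same position on the ring. The step of an at least 3.4-fold lower number from compound 1 to compound 3 (0.53 log units; beyond the scatter) shows that trifluoromethyl gave a clearly lower number than methoxy, and an at least 2.6-fold lower number from compound 1 to compound 2 (0.42 log units; beyond the scatter) shows the same for chloro. Among the three groups tried so far, the one carrying oxygen gave the weaker growth inhibition, while the two without oxygen were close to each other. Methoxycarbonyl, which also carries oxygen, has not been tried, so the comparison stays loose. The expected step is a 2.1-fold higher number from compound 3 to compound 4 (0.31 log units; beyond the scatter), toward a higher number. Compound 4 is therefore estimated to give about 60000 nM, with a range from 20000 nM to 150000 nM.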

Compound 4, concentration for 50% growth inhibition: 22900 nM
Compound 4: middle estimate off by 2.6-fold (0.42 log units), on the high side; the measured number falls inside the stated range.
By their numbers in this assay, from the lowest: compounds 4, 3 and 2 (each within the scatter of the next). At a limit, above all of these: compound 1.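

The step of a 1.3-fold lower number from compound 3 to compound 4 (0.10 log units; within the scatter) and the step of a 1.6-fold lower number from compound 2 to compound 4 (0.22 log units; within the scatter) both lie within the scatter, so in this assay methoxycarbonyl cannot be told apart from trifluoromethyl or chloro at this place, even though it brings in hydrogen-bond acceptors that trifluoromethyl lacks. The earlier hint that a group carrying oxygen goes with weaker growth inhibition therefore does not hold across these four compounds: compound 1 fits it, compound 4 goes against it, and the step of an at least 4.3-fold lower number from compound 1 to compound 4 (0.64 log units; beyond the scatter) sets methoxy apart from methoxycarbonyl, although both carry oxygen. The size of that step stays open-ended, since compound 1 gives a limit and not a number: the limit of > 100000 nM in this assay, at which 1 of the 4 values shown sits.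

Going by these compounds, with only four groups at this place, it remains open whether a carboxylic acid, an amine or a longer chain such as an ethoxycarbonyl group would stand apart from the three groups that cannot be separated here. All four compounds also share the rest of the structure, so these steps say nothing about how this position would behave if another part of the shared core were changed.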